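The source may report more compounds than this note shows. Statements on the series, on what has been measured and on what is new or still open speak of the compounds shown alone.

Compound 1 `COc1cc(-c2nn(-c3cccc(NC(=O)c4cccc(C(F)(F)F)c4)c3)cc2-c2ccncc2)ccc1Cl` is the starting point of this account. In a functional assay on Malme-3M cells (Homo sapiens) for inhibition, read by sulforhodamine B assay, with a stated time of 48 h (a higher number here means a weaker inhibitor of growth, a lower number a stronger inhibitor of growth), compound 1 returns only a limit, > 50000 nM, so its true potency is not known; it sits at the limit of > 50000 nM in this assay, at which 1 of the 3 values shown sits. Two related ureas were also measured, though each differs from compound 1 in more than one place. Compound 2 `O=C(Nc1cccc(-n2cc(-c3ccncc3)c(-c3ccc(Cl)c(O)c3)n2)c1)Nc1cc(C(F)(F)F)cc(C(F)(F)F)c1` gives 3030 nM in this assay. Compound 3 `O=C(Nc1cccc(-n2cc(-c3ccncc3)c(-c3ccc(Cl)c(O)c3)n2)c1)Nc1ccc(Cl)c(C(F)(F)F)c1` gives 1650 nM in this assay. Both of these values lie within the scatter of each other, so no order between compound 2 and compound 3 can be read from them.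

The step from compound 1 to compound 4 `COc1cc(-c2nn(-c3cccc(NC(=O)Nc4ccc(Cl)c(Cl)c4)c3)cc2-c2ccncc2)ccc1Cl` changes the amide into a urea: (3,4-dichlorophenyl)amino in place of 3-(trifluoromethyl)phenyl on a carbonyl carbon. Since compound 1 is known only as a limit, the size of this step cannot be measured directly. Given that compound 2 gives 3030 nM and compound 3 gives 1650 nM as ureas, a move toward measurable growth inhibition is expected, of the size an at least 8.3-fold lower number from compound 1 to compound 4 (0.92 log units; beyond the scatter). Compound 4 is therefore estimated at 6000 nM in this assay, with a range from 1200 nM to 50000 nM.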

Compound 4, concentration for total growth inhibition: 2420 nM
Compound 4: middle estimate off by 2.5-fold (0.39 log units), on the high side, and the stated range covers the measured number.
By their numbers in this assay, from the lowest: compounds 3, 4 and 2 (each within the scatter of the next). At a limit, above all of these: compound 1.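

For the compounds shown here, on a carbonyl carbon, (3,4-dichlorophenyl)amino in place of 3-(trifluoromethyl)phenyl gives an at least 20-fold lower number from compound 1 to compound 4 (1.31 log units; beyond the scatter), and this is the first comparison here that differs in one place only. With the rest of compound 1 kept, this single change is enough to reach a measured number in this assay, where compound 4 gives 2420 nM. The true size of the step remains unknown, because compound 1 stands at a limit: the limit of > 50000 nM in this assay, at which 1 of the 4 values shown sits.

The change replaces the aryl group and adds the amino nitrogen together, so the compounds shown do not separate the share of each. Going by these compounds, it also remains open how a methylene or an oxygen in place of that amino nitrogen would read in this assay.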